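Cytotoxicity of a Shared Core Under a Benzyl-for-Prenyl Swap

A few compounds are considered here, and "the series" means these few. Any claim that something is new, unique, unknown or untested is made for them only; others in the source may bear on it.

Compound 1, `CC(C)=CCN1C(=O)N(Cc2ccccc2)S(=O)(=O)n2cccc21`: 226000 nM
Compound 2, `N#Cc1ccccc1CN1C(=O)N(Cc2cccc(Cl)c2)S(=O)(=O)n2cccc21`: > 293000 nM (a limit of the assay)
Compound 3, `N#CCN1C(=O)N(Cc2cccc(F)c2)S(=O)(=O)n2cccc21`: 172000 nM

Of the compounds shown here, three on a shared core have been tested in an ADME assay on MT4 cells (Homo sapiens) for cytotoxicity, read by MTT assay, with a stated time of 5 days; on this read-out higher numbers stand for lower toxicity in this test and lower numbers for higher toxicity in this test. Compound 1 gives 226000 nM there, the highest of the two plain numbers. Compound 3 gives 172000 nM in this assay, which lies within the scatter of the number for compound 1, so the two cannot be ordered. For compound 2 this assay reports only a limit, (the limit of > 293000 nM in this assay, at which 1 of the 3 values shown sits), and not a number.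

Compound 4, `O=C1N(Cc2ccc(F)cc2)c2cccn2S(=O)(=O)N1Cc1ccccc1`, has not yet been measured in this assay. Compared with compound 1 it carries 4-fluorophenyl in place of 2-methylprop-1-en-1-yl on a saturated chain carbon bound to an amide-type nitrogen in a ring. Among the compounds with values here, nothing among the measured compounds isolates this change, and the variation across the three measured compounds is small. The step from compound 1 to compound 4 in this assay is therefore expected to be modest, and it may well fall within the scatter in either direction. Compound 4 is estimated to give 200000 nM in this assay, within a range from 100000 nM to 320000 nM, which corresponds to an expected step of a 1.1-fold lower number from compound 1 to compound 4 (0.05 log units; within the scatter).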

Compound 4, half-maximal cytotoxic concentration: 150000 nM
Beside the measured number, compound 4's estimate is 1.3-fold (0.12 log units) above it; the range from low to high includes it.
By their numbers in this assay, from the lowest: compounds 4, 3 and 1 (each within the scatter of the next). At a limit, above all of these: compound 2.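

In this assay, within the data shown here, the change from 3-methylbut-2-en-1-yl to 4-fluorobenzyl gives a 1.5-fold lower number from compound 1 to compound 4 (0.18 log units; within the scatter), the first step on the shared core that can be read between two compounds differing in one place. It shows that, on a saturated chain carbon bound to an amide-type nitrogen in a ring, a 4-fluorophenyl group can replace 2-methylprop-1-en-1-yl without a change that stands out from the scatter, even though a chain with a double bond gives way to an aromatic ring of carbon only. Nothing measured among the compounds shown offers a reason for this step, and none of it bears on how either group acts in these cells.

The compounds shown leave open whether this tolerance is particular to these two groups or extends to quite different ones at the same place, such as an amine, a carboxylic acid or a longer chain. They also leave open what the fluorine contributes, since a plain benzyl group in this place, with the rest of compound 4 unchanged, does not appear among them.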